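Following compound 1 to compound 3

This account rests on a few compounds, and the source may have more. Where it says the series, first, only, none or still open, it means among the compounds named here.

Compound 1 (`COc1cc(/C=C/c2ccccc2)c(-c2ccccc2)c(OC)c1OC`) gives (79000 nM)
Compound 2 (`C=C(c1ccc(OC)cc1)c1cc(OC)c(OC)c(OC)c1-c1ccc(F)c(F)c1`) gives (6500 nM)

In a functional assay on A549 cells (Homo sapiens) for cytotoxicity, read by MTT assay, with a stated time of 48 h (on this read-out higher numbers stand for weaker inhibition and lower numbers for stronger inhibition), compound 1 stands highest of the two numbers, with compound 2 lower by a margin beyond the scatter. Compound 3 (`C=C(c1ccc(C)cc1)c1cc(OC)c(OC)c(OC)c1-c1ccccc1`) differs from compound 1 in one place (1-(4-methylphenyl)ethenyl in place of 2-phenylethenyl on an aromatic carbon): 1-(4-methylphenyl)ethenyl in place of 2-phenylethenyl on an aromatic carbon. Within the data shown here, no measured step covers this change. Among the measured compounds shown here, the only guide is compound 2 (6500 nM), which carries a related ethenyl group but differs elsewhere too. A lower number, beyond the scatter, is therefore expected in this assay (a 5.3-fold lower number from compound 1 to compound 3 (0.72 log units; beyond the scatter)). Compound 3 is estimated at 15000 nM with a range (4000 nM to 50000 nM).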

Compound 3, half-maximal inhibitory concentration: 35000 nM
For compound 3 the middle estimate is 2.3-fold (0.37 log units) below the measured one; the measured number falls inside the stated range.
By their numbers in this assay, from the lowest: compound 2; then compound 3; then compound 1.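

In this assay, placing 1-(4-methylphenyl)ethenyl instead of 2-phenylethenyl on the aromatic carbon ortho to a phenyl group gives a 2.3-fold lower number from compound 1 to compound 3 (0.35 log units; beyond the scatter), a modest step. Among these compounds, this is the first single-place comparison at this position, and it shows that the read-out responds to this change beyond the scatter. Nothing available explains the step. On these data alone, the methyl group and the altered attachment of the ring to the ethenyl group change together, so their separate shares remain open. As far as these compounds go, how an amine or a carboxylic acid in place of that methyl group would read also remains open.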